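This account rests on a few compounds, and the source may have more. Where it says the series, first, only, none or still open, it means among the compounds named here.

Measured so far in a functional assay on HepG2 cells (Homo sapiens) for antiproliferative activity, read by MTT assay, with a stated time of 48 h (a higher number here means a weaker inhibitor, a lower number a stronger inhibitor), on the shared core:
- compound 1 `CCn1c(C(=O)NCC#N)ccc1C(CC)(CC)c1ccc(OCCC(O)(CC)CC)c(C)c1` gives > 50000 nM as a limit
- compound 2 `CCn1c(C(=O)NC(C)C(=O)O)ccc1C(CC)(CC)c1ccc(OCCC(O)(CC)CC)c(C)c1` gives 1740 nM as a number

Within the data shown here, compound 2 holds the only actual number, as the other value is a limit. Compound 3 `CCC(C)C(CO)NC(=O)c1ccc(C(CC)(CC)c2ccc(OCCC(O)(CC)CC)c(C)c2)n1CC` is not yet measured. It carries 1-(hydroxymethyl)-2-methylbutyl in place of 1-carboxyethyl on an amide-type nitrogen, and the change counts as 1-(hydroxymethyl)-2-methylbutyl in place of 1-carboxyethyl on an amide-type nitrogen in full.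

Among the measured compounds shown here, one measured step bears on this, an at least 28-fold lower number from compound 1 to compound 2 (1.45 log units; beyond the scatter) at the same nitrogen, which is large and beyond the scatter. It brought in the 1-carboxyethyl group that compound 3 now gives up, so part of that gain may be lost, though a single step is thin support.

Expected in this assay is a 3.4-fold higher number from compound 2 to compound 3 (0.54 log units; beyond the scatter) toward a higher number, meaning a weaker inhibitor. The estimate for compound 3 is 6000 nM with an expected range from 1200 nM to 30000 nM at this stage.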

Compound 3, half-maximal inhibitory concentration: > 50000 nM
Compound 3 gave a limit, no number; the forecaster's own chance of this, stated with the estimate: 25%; middle value at least 8.3-fold (0.92 log units) from the limit.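

Replacing 1-carboxyethyl with 1-(hydroxymethyl)-2-methylbutyl on the amide-type nitrogen in this assay gives an at least 28-fold higher number from compound 2 to compound 3 (1.45 log units; beyond the scatter). Among these compounds, a second replacement at this nitrogen therefore also fails to keep the activity of compound 2, which remains the only one of the three compounds with an actual number. Compound 1 and compound 3 both stand at a limit, so the step between them cannot be read: the limit of > 50000 nM in this assay, at which 2 of the 3 values shown sit.

This step both removes the carboxylic acid and lengthens the chain, and the compounds shown do not separate these two changes. A 1-carboxy-2-methylbutyl group, with the acid on the longer chain, and a 1-(hydroxymethyl)ethyl group, with the shorter chain and no acid, would bear directly on that question.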